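A few compounds are considered here, and "the series" means these few. Any claim that something is new, unique, unknown or untested is made for them only; others in the source may bear on it.

Measured so far:
- compound 1 `COc1cccc([C@H]2CC[C@@H](NCCOc3ccccn3)CC2)c1`: 7.71 nM
- compound 2 `Clc1ccccc1[C@H]1CC[C@@H](N2CCN(c3ccccn3)CC2)CC1`: 1090 nM

Of the compounds shown here, two have been tested in an assay on membranes from brain for displacement of a labelled ligand from Sigma non-opioid intracellular receptor 1 (Cavia porcellus); on this read-out higher numbers stand for weaker inhibition and lower numbers for stronger inhibition. Compound 1 gives 7.71 nM in this assay. Compound 2, which shares the saturated ring flanked by an aromatic ring on one side and a nitrogen on the other, gives 1090 nM in this assay, the higher of the two numbers and therefore the weaker of the two; the gap to compound 1 is well beyond the scatter of repeated measurements.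

The next compound, compound 3 `Clc1ccccc1[C@H]1CC[C@H](N2CCN(c3ccccn3)CC2)CC1`, is the stereochemical partner of compound 2. The change is the two compounds have the same atoms and bonds and differ only in configuration as drawn: 2 of 2 stereo elements differ (all stereocentres are inverted: mirror images); a stereocentre at a saturated ring carbon is drawn s in compound 2 and r in compound 3; a stereocentre at a saturated ring carbon is drawn s in compound 2 and r in compound 3. Nothing is removed and nothing is added; only the spatial arrangement at the two ring carbons is changed.

Within the data shown here, no measured pair in this set shows what such an inversion does in this assay, so the direction of the step is open. Because compound 2 stands at 1090 nM, the expected step from compound 2 to compound 3 is a 3.1-fold lower number from compound 2 to compound 3 (0.49 log units; beyond the scatter), with a wide margin either way. Compound 3 is estimated at 350 nM, within a range from 50 nM to 3000 nM.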

Compound 3, inhibition constant: 190 nM
For compound 3 the middle estimate is 1.8-fold (0.27 log units) above the measured one; the range from low to high includes it.
By their numbers in this assay, from the lowest: compound 1; then compound 3; then compound 2.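

Inverting both saturated ring carbons gives a 5.7-fold lower number from compound 2 to compound 3 (0.76 log units; beyond the scatter) in this assay, so this read-out tells the two mirror images apart. Among these compounds, this is the first measured sign in the set that configuration alone can move the number, with every atom and bond left in place. The shift can be assigned to the spatial arrangement at those two carbons, because nothing else separates the pair: the fact that compounds 2 and 3 differ only in the configuration as drawn

This is a single pair, however, so it gives the direction and size of the inversion for this one structure, and no general rule follows from it. Still open, going by these compounds, is whether the same inversion would shift the number in the same direction and by a similar amount in compound 1, whose ring carries a different aromatic group and an open chain on its nitrogen, and whether the preference for one configuration would survive if a fluorine or a nitrile took the place of the chlorine.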